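Replacing a Ring Hydrogen with Pyridin-4-yl

The source may hold more compounds than are shown below. What is called first, only, known or untested is meant among the compounds shown, and "the series" means these compounds.

Measured so far in an assay on membranes from brain for binding affinity to adenosine receptor A1 (Rattus norvegicus), read by radioligand binding; on this read-out higher numbers stand for weaker inhibition and lower numbers for stronger inhibition:
compound 1 `Cc1nn(C)c2c(O)ncnc12` gives 20100 nM
compound 2 `Cc1nn(C)c2c(O)nc(Cc3ccccc3)nc12` gives 1310 nM
compound 3 `Cn1c(=O)c2nc(Cc3ccccc3)[nH]c2n(C)c1=O` gives 1500 nM

Compound 1 stands at the highest of these three numbers, that is, at the weakest inhibition. Compound 3 lies nearest to it and compound 2 furthest, and both gaps are beyond the scatter. Among the compounds with values here, compound 2 carries a benzyl group where compound 1 carries only a hydrogen, while compound 3 is built on a different core, so no pair of measured compounds differs in just one place.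

Compound 4 `Cc1nn(C)c2c(O)nc(-c3ccncc3)nc12` differs from compound 1 in a single way: pyridin-4-yl in place of hydrogen on an aromatic carbon. For this change a clear step toward stronger inhibition, beyond the scatter, is expected in this assay, because compound 2 at 1310 nM shows that an aromatic group in place of that hydrogen lowers the number sharply. Compound 4 is therefore estimated at about 2000 nM, with a range from 500 nM to 8000 nM. This expectation corresponds to a step of a 10-fold lower number from compound 1 to compound 4 (1.00 log units; beyond the scatter).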

Compound 4, half-maximal inhibitory concentration: 950 nM
Estimate against measurement, compound 4: 2.1-fold (0.32 log units) above; low and high end bracket the measured number.
By their numbers in this assay, from the lowest: compounds 4, 2 and 3 (each within the scatter of the next); then compound 1.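

In this assay, within the data shown here, this is the first change at a single place that can be read on the shared core: pyridin-4-yl on the aromatic carbon between two ring nitrogen atoms gives a 21-fold lower number from compound 1 to compound 4 (1.33 log units; beyond the scatter), a large step toward stronger inhibition. Compound 2, with benzyl at that same carbon, gives 1310 nM and compound 4 gives 950 nM, two values within the scatter of each other, so a ring attached directly to this carbon does as well here as one attached through benzyl. Nothing measured here explains why this step is so large.

A plain phenyl ring on this carbon would show whether the ring nitrogen of pyridin-4-yl matters. A methyl group or an amine there would show whether a ring is needed at all.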